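The source may report more compounds than this note shows. Statements on the series, on what has been measured and on what is new or still open speak of the compounds shown alone.

Measured so far in an ADME assay on Vero cells (Chlorocebus sabaeus) for cytotoxicity; on this read-out higher numbers stand for lower toxicity in this test and lower numbers for higher toxicity in this test:
compound 2 `Fc1ccc(-c2nn3c(NC4CCCC4)cccc3c2-c2cc[nH]n2)cc1`: 14000 nM
compound 3 `Fc1ccc(-c2nn3c(NC4CCCC4)cccc3c2-c2ccc3[nH]ccc3c2)cc1`: 20000 nM
compound 1 `Fc1ccc(-c2nn3c(NC4CCCC4)cccc3c2-c2ccnc(F)c2)cc1`: "not determined" (no result reported)

Compound 3 carries a 1H-indol-5-yl group where compound 2 carries 1H-pyrazol-3-yl. In this assay compound 3 gives 20000 nM, and compound 2 gives 14000 nM; the two sit within the scatter of each other, a 1.4-fold higher number from compound 2 to compound 3 (0.15 log units; within the scatter). Compound 1 has no result in this assay, so nothing can be drawn from it.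

Compound 4 `Nc1n[nH]cc1-c1c(-c2ccc(F)cc2)nn2c(NC3CCCC3)cccc12` is compound 3 with 3-amino-1H-pyrazol-4-yl in place of 1H-indol-5-yl on an aromatic carbon. Within the data shown here, the only measured step that bears on this is the exchange of a five-membered aromatic group for the 1H-indol-5-yl group, which gave a 1.4-fold higher number from compound 2 to compound 3 (0.15 log units; within the scatter). Compound 4 goes back toward a five-membered aromatic ring with 2 hetero atoms, now carrying 2 hydrogen-bond donors and 2 hydrogen-bond acceptors. With a single comparable step available, and that one within the scatter, no movement beyond the scatter in this assay is expected from compound 3 to compound 4. Compound 4 is therefore estimated at 16000 nM, with a range from 7000 nM to 40000 nM. The expected step is a 1.3-fold lower number from compound 3 to compound 4 (0.10 log units; within the scatter).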

Compound 4, half-maximal cytotoxic concentration: 20000 nM
Beside the measured number, compound 4's estimate is 1.3-fold (0.10 log units) below it; the measured number falls inside the stated range.
By their numbers in this assay, from the lowest: compounds 2, 3 and 4 (each within the scatter of the next).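

At this position, on an aromatic carbon of the five-membered aromatic ring with 2 nitrogen, this assay shows no change at the digits printed from compound 3 to compound 4 (within the scatter) when 3-amino-1H-pyrazol-4-yl replaces 1H-indol-5-yl, although the group goes from 9 heavy atoms to 6, from 1 hydrogen-bond donor to 2, and from 0 hydrogen-bond acceptors to 2. Between the two groups with a five-membered aromatic ring with 2 hetero atoms, the same read-out gives a 1.4-fold higher number from compound 2 to compound 4 (0.15 log units; within the scatter) and so separates neither of these exchanges from the scatter; across compounds 2, 3 and 4, this position has so far tolerated single and fused aromatic groups alike, with or without the amino substituent. No measured data are available to account for this flat picture.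

Still open, going by these compounds, is whether a group of another kind at this aromatic carbon, such as a carboxylic acid, a saturated ring amine like piperidine or a longer alkyl chain, would move the number beyond the scatter. The compounds shown also leave open whether the same holds once the 4-fluorophenyl group on the neighbouring ring atom is replaced by a group such as a methyl or a carboxamide.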